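One Ring Swapped: From Compound 1 to Compound 4

This account rests on a few compounds, and the source may have more. Where it says the series, first, only, none or still open, it means among the compounds named here.

Compound 1 `N#Cc1ccc(Nc2nc(Oc3ccc(Cl)cc3)c3ccccc3n2)cc1` gives 198000 nM in an ADME assay on MT4 cells (Homo sapiens) for cytotoxicity, read by MTT assay, with a stated time of 4 days; a lower number here means that less compound is tolerated, a higher number that more compound is tolerated.
Compound 2 `CCCOc1cc(C#N)cc(OC)c1Oc1nc(Nc2ccc(C#N)cc2)nc2ccccc12` gives 5200 nM in this assay.
Compound 3 `CCOc1cc(C#N)cc(Cl)c1Oc1nc(Nc2ccc(C#N)cc2)nc2ccccc12` gives 22000 nM in this assay.

Among these three, compound 1 stands highest: its gap to compound 3, the nearest, and to compound 2, the furthest, both lie beyond the usual scatter of repeated measurements. Compound 1 is thus the one of which the cells tolerate the most.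

Compound 4 `Cc1ccccc1Oc1nc(Nc2ccc(C#N)cc2)nc2ccccc12` has not yet been measured. It differs from compound 1 in a single place: 2-methylphenyl in place of 4-chlorophenyl on an oxygen on an aromatic ring. Both the group that leaves and the group that enters are one six-membered aromatic ring of carbon only, of the same heavy-atom count, with no hydrogen-bond donors or acceptors and no charge.

Among the compounds with values here, no measured pair in this set shares this kind of exchange, so nothing here shows directly what it does to tolerated concentration. Given how alike the two groups are in what is counted, the expected step is a 1.3-fold lower number from compound 1 to compound 4 (0.12 log units; within the scatter), a change no larger than the usual scatter, if anything slightly downward. Compound 4 is therefore estimated at 150000 nM, with a range from 50000 nM to 300000 nM.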

Compound 4, half-maximal cytotoxic concentration: 355000 nM
Estimate against measurement, compound 4: 2.4-fold (0.37 log units) below; the measured number lies above the stated range.
By their numbers in this assay, from the lowest: compound 2; then compound 3; then compounds 1 and 4 (each within the scatter of the next).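

Within the data shown here, this is the first direct look at an exchange on this oxygen: in this assay, 2-methylphenyl in place of 4-chlorophenyl gives a 1.8-fold higher number from compound 1 to compound 4 (0.25 log units; within the scatter), so the read-out does not tell compound 1 and compound 4 apart. For this pair, moving from a ring that carries chlorine to a ring of the same heavy-atom count that carries a methyl group leaves the tolerated concentration within the usual scatter of repeated measurements. Nothing measured here explains why the two compounds behave alike in these cells.

The compounds shown leave open whether the same holds for a ring on this oxygen that carries an amine or a carboxylic acid, or a longer chain in place of the methyl group. This exchange also alters both the substituent and its place on the ring in one step, so it cannot separate the two changes; an unsubstituted phenyl group, or 4-methylphenyl, at the same oxygen would be needed to tell them apart.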